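This account rests on a few compounds, and the source may have more. Where it says the series, first, only, none or still open, it means among the compounds named here.

Compound 1, `O=C(N/N=C/c1ccccc1)c1cccnc1Nc1cccc(C(F)(F)F)c1`: 31%
Compound 2, `O=C(N/N=C/c1ccc(Cl)cc1)c1cccnc1Nc1cccc(C(F)(F)F)c1`: 43.7%
Compound 3, `O=C(N/N=C/c1ccc(O)c(O)c1)c1cccnc1Nc1cccc(C(F)(F)F)c1`: 21.1%

In a functional assay on the whole organism (strain Wistar) for inhibition, with Rattus norvegicus as the target, read by paw edema, with a stated time of 4 h, at a dose of 10 mg/kg by the intraperitoneal route (on this read-out lower numbers stand for less inhibition and higher numbers for more inhibition at the one dose given (going by the name of the read-out)), compound 3 stands lowest of the three numbers; its gap to compound 1 is within the scatter, its gap to compound 2 beyond it. Compound 4, `COc1ccc(/C=N/NC(=O)c2cccnc2Nc2cccc(C(F)(F)F)c2)cc1`, differs from compound 3 in one place: 4-methoxyphenyl in place of 3,4-dihydroxyphenyl on a carbon with a double bond to nitrogen. Among the measured compounds shown here, no measured step makes this exact exchange. Bearing on it are a number 9.9 percentage points lower from compound 1 to compound 3 (within the scatter), within the scatter, and a number 22.6 percentage points lower from compound 2 to compound 3 (beyond the scatter), beyond the scatter, which together show the 3,4-dihydroxyphenyl compound giving the smaller number; a number 12.7 percentage points higher from compound 1 to compound 2 (beyond the scatter) shows a substituent on that ring raising it. A modest rise is therefore expected, a step of a number 13.9 percentage points higher from compound 3 to compound 4 (beyond the scatter). Compound 4 is estimated at 35%, with a range from 20% to 50%.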

Compound 4, a percentage reported as inhibition, in the whole organism at one dose (the size of the read-out at that dose, not a potency): 14%
Compound 4: the middle estimate sits 21 percentage points above what was measured; the whole stated range lies above it.
By their numbers in this assay, from the lowest: compounds 4, 3 and 1 (each within the scatter of the next, the first and the last beyond it); then compound 2.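

In this assay, a substituent on this ring does not by itself raise the number: methoxy in place of hydrogen brings a fall (a number 17 percentage points lower from compound 1 to compound 4 (beyond the scatter)), and methoxy in place of chloro a larger one (a number 29.7 percentage points lower from compound 2 to compound 4 (beyond the scatter)). The rise seen with chloro is therefore not shared by methoxy, while 4-methoxyphenyl and 3,4-dihydroxyphenyl are not told apart (a number 7.1 percentage points lower from compound 3 to compound 4 (within the scatter)). Nothing available explains this difference between chloro and methoxy. As far as these compounds go, whether bromo would follow chloro remains open, as does the effect of an amine or a carboxylic acid on this ring.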